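Lengthening the Hydroxyl Chain from Compound 2 to Compound 3

The source may report more compounds than this note shows. Statements on the series, on what has been measured and on what is new or still open speak of the compounds shown alone.

Compound 2 `OCc1cn[nH]c1` carries a hydroxy group on a saturated chain carbon bound to an aromatic carbon. Among the compounds with values here, in an assay for inhibition of alcohol dehydrogenase (Equus caballus), read by spectrophotometry, in the presence of a further agent that is not named here (a lower number here means tighter binding, a higher number weaker binding), compound 2 gives 3600 nM, the higher of the two numbers measured so far. Its nearest neighbour is compound 1 `ClCCCc1cn[nH]c1`, which in this assay gives 20 nM; the step of a 180-fold higher number from compound 1 to compound 2 (2.26 log units; beyond the scatter) shows how much weaker binding became when 2-chloroethyl was replaced by hydroxy. Compound 3 `OCCCc1cn[nH]c1` has not yet been measured. It differs from compound 2 by 2-hydroxyethyl in place of hydroxy on a saturated chain carbon bound to an aromatic carbon, so the chain is lengthened again while a hydroxyl is kept. Within the data shown here, only that one step bears on this change, and it altered chain length and the halogen together, so the present change recovers only part of it. A lower number is therefore expected, short of compound 1. Compound 3 is estimated at 200 nM, within 50 nM to 800 nM, an expected step of an 18-fold lower number from compound 2 to compound 3 (1.26 log units; beyond the scatter).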

Compound 3, dissociation constant: 560 nM
Beside the measured number, compound 3's estimate is 2.8-fold (0.45 log units) below it; the range from low to high includes it.
By their numbers in this assay, from the lowest: compound 1; then compound 3; then compound 2.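

Keeping the hydroxyl and lengthening the chain gives a 6.4-fold lower number from compound 2 to compound 3 (0.81 log units; beyond the scatter), so chain length on its own moves binding, something the earlier step could not show as it changed the chain and the end group together. With the chain length held, the end group also counts: the other new step gives a 28-fold higher number from compound 1 to compound 3 (1.45 log units; beyond the scatter), and this change of chloro to hydroxy is printed as large, while the lengthening is printed as modest. No measurement here explains why either change shifts binding as it does.

The compounds shown leave open whether a chain longer than that of compound 3 would tighten binding further. They also leave open how a chain of the same length as in compound 3 would behave if it ended in an amine, a carboxylic acid or a bromo group.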